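Swapping Bromo for Hydroxy in Two Related Pairs

The compounds below may be only part of what the source reports. "The series", "measured", "known", "first", "only" and "open" are said of these compounds alone.

Compound 1 `O=C1/C(=C/c2ccccc2Br)CCc2cc(O)ccc21` and compound 2 `O=C1/C(=C/c2ccccc2O)CCc2cc(O)ccc21` share a core and differ by hydroxy in place of bromo on an aromatic carbon. In a functional assay on RAW264.7 cells (Mus musculus) for inhibition (a lower number here means a stronger inhibitor, a higher number a weaker inhibitor), compound 1 gives 1070 nM, and compound 2 gives 550 nM. The step between them is a 1.9-fold lower number from compound 1 to compound 2 (0.29 log units; within the scatter). Compound 3 `O=C1/C(=C/c2cccc(Br)c2)CCc2ccc(O)cc21` has the same atoms as compound 1, joined differently; the difference between the two cores is not broken down here. In this assay compound 3 gives 480 nM. Compound 4 `O=C1/C(=C/c2cccc(O)c2)CCc2ccc(O)cc21` is not yet measured and differs from compound 3 by hydroxy in place of bromo on an aromatic carbon. This is the same kind of change as in the first pair, but the place is not identical: ortho to a large group there, meta to a large group here. A step of similar size is expected, namely a 1.6-fold lower number from compound 3 to compound 4 (0.20 log units; within the scatter). Compound 4 is estimated at 300 nM, with a likely range from 150 nM to 650 nM.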

Compound 4, half-maximal inhibitory concentration: 810 nM
Compound 4: the middle estimate sits 2.7-fold (0.43 log units) below what was measured; measured number outside the range, above it.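

On the core of compound 3, hydroxy in place of bromo gives a 1.7-fold higher number from compound 3 to compound 4 (0.23 log units; within the scatter) in this assay. Set beside the first pair, this shows that the change does not carry from one core to the other as a fixed step: the same change on two cores in this assay, a 1.9-fold lower number (0.29 log units; within the scatter) from compound 1 to compound 2 and a 1.7-fold higher number (0.23 log units; within the scatter) from compound 3 to compound 4, 3.3-fold (0.52 log units) apart, beyond the scatter of two such steps

It does not show whether the core or the place on the ring accounts for this, since the two pairs differ in both, and neither step alone lies beyond the scatter.

Still open, on these data alone, is what the same change does when it sits at one identical place on both cores. Also open, as far as these compounds go, is whether another group there, such as an amine or a carboxylic acid, would follow either step.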